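The source may report more compounds than this note shows. Statements on the series, on what has been measured and on what is new or still open speak of the compounds shown alone.

Compound 1 `CS(=O)(=O)c1ccc(C(=O)N2CCC(C(=O)N3CCc4ccccc43)CC2)cc1[N+](=O)[O-]` is the starting point. In an assay on isolated protein for inhibition of vitamin D3 receptor (Homo sapiens), read by fluorescence polarization (a lower number here means a stronger inhibitor, a higher number a weaker inhibitor), compound 1 reaches only the limit of the assay, > 60000 nM, so no number is known for it. Compound 2 `CS(=O)(=O)c1ccc(C(=O)NCC(=O)N2CCN(c3ccccc3F)CC2)cc1[N+](=O)[O-]` also gives only a limit in this assay, > 60000 nM. Within the data shown here, both values shown therefore sit at the same boundary (the limit of > 60000 nM in this assay, at which 2 of the 2 values shown sit), and no step between measured compounds can be read off.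

Compound 3 `CS(=O)(=O)c1ccc(C(=O)N2CCC(C(=O)N3CCc4ccccc4C3)CC2)cc1[N+](=O)[O-]` has not yet been measured in this assay. It differs from compound 1 by 1,2,3,4-tetrahydroisoquinolin-2-yl in place of 2,3-dihydro-1H-indol-1-yl on a carbonyl carbon, an exchange of one two-ring group for another of similar size. With both known compounds at the limit, no step beyond the usual scatter is expected from this exchange. Compound 3 is therefore expected to sit near 90000 nM, between 30000 nM and 300000 nM, most likely again as a limit. The expected change a step that the limit leaves unreadable from compound 1 to compound 3 is essentially none.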

Compound 3, half-maximal inhibitory concentration: > 60000 nM
Compound 3 gave a limit, no number (the forecaster's own chance of this, stated with the estimate: 85%); the middle value does not contradict the limit.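

Compound 1 and compound 3 both give only a limit in this assay, so 1,2,3,4-tetrahydroisoquinolin-2-yl in place of 2,3-dihydro-1H-indol-1-yl produces no readable step: the limit of > 60000 nM in this assay, at which 3 of the 3 values shown sit.

The compounds shown leave open how strongly any of them inhibits the receptor, and whether these two groups differ at all.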